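Replacing the Morpholinylcarbonyl Group with an Imidazolyl Ring

The compounds below may be only part of what the source reports. "The series", "measured", "known", "first", "only" and "open" are said of these compounds alone.

Of the compounds shown here, three on a shared core have been tested in an assay on isolated protein for inhibition of serine protease 1 (Bos taurus); on this read-out lower numbers stand for stronger inhibition and higher numbers for weaker inhibition. Compound 1 `Cc1c(F)c(Oc2cccc(N)c2)nc(Oc2cccc(C(=N)N)c2)c1F` carries an amino group on one of its outer rings; in this assay compound 1 returns only a limit of the assay, > 5000 nM. Compound 2 `Cc1c(F)c(Oc2cccc(NS(C)(=O)=O)c2)nc(Oc2cccc(C(=N)N)c2)c1F` carries a methanesulfonamido group in its place and gives 1900 nM in this assay, which is an at least 2.6-fold lower number from compound 1 to compound 2 (0.42 log units; beyond the scatter). Compound 3 `Cc1c(F)c(Oc2cccc(C(=N)N)c2)nc(Oc2cccc(C(=O)N3CCOCC3)c2)c1F` carries a (morpholin-4-yl)carbonyl group on that ring. In this assay compound 3 also returns only a limit of the assay, > 5000 nM. Compound 3 thus stands at the limit of > 5000 nM in this assay, at which 2 of the 3 values shown sit; the step to it from compound 2 is an at least 2.6-fold higher number from compound 2 to compound 3 (0.42 log units; beyond the scatter), while the step that the two limits leave unreadable from compound 1 to compound 3 cannot be read.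

Compound 4 `Cc1c(F)c(Oc2cccc(C(=N)N)c2)nc(Oc2cccc(-n3ccnc3)c2)c1F` differs from compound 3 in one place: 1H-imidazol-1-yl in place of (morpholin-4-yl)carbonyl on an aromatic carbon. Among the compounds with values here, the one measured step that bears on this part of the molecule is an at least 2.6-fold higher number from compound 2 to compound 3 (0.42 log units; beyond the scatter), and the change from compound 1 to compound 3 gave no readable size. Within the data shown here, compound 3 sits at a limit, and no measured step involves an imidazolyl group, so the direction of the new step is open. Compound 4 is therefore expected to remain weak, with an estimated 5000 nM (range 1500 nM to 20000 nM), which would mean an expected step of a number no higher from compound 3 to compound 4 (the limit leaves the size open).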

Compound 4, inhibition constant: 4800 nM
Estimate against measurement, compound 4: 1.0-fold (0.02 log units) above; the measured number falls inside the stated range.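

In this assay, the 1H-imidazol-1-yl group joins methanesulfonamido as a second group on this aromatic carbon that returns a number rather than a limit of the assay, but this adds little to the comparison with the two compounds that sit at the limit: the result is an at least 1.0-fold lower number from compound 3 to compound 4 (0.01 log units; that floor lies within the scatter), and likewise an at least 1.0-fold lower number from compound 1 to compound 4 (0.01 log units; that floor lies within the scatter). The methanesulfonamido group keeps a measurable edge, with a 2.5-fold higher number from compound 2 to compound 4 (0.40 log units; beyond the scatter), and compound 2 is the strongest of the four compounds shown. Exchanging the (morpholin-4-yl)carbonyl group for a five-membered aromatic ring, with the count of hydrogen-bond acceptors unchanged, therefore does not bring the number down to that of compound 2.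

As far as these compounds go, compound 1 and compound 3 remain limits of the assay, so how far either lies from compound 4 stays unknown: the limit of > 5000 nM in this assay, at which 2 of the 4 values shown sit. It also stays open whether an ethanesulfonamido group, a methanesulfonamido group carrying a methyl on its nitrogen, or a 1H-pyrazol-1-yl ring on this aromatic carbon would match or pass compound 2.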